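A few compounds are considered here, and "the series" means these few. Any claim that something is new, unique, unknown or untested is made for them only; others in the source may bear on it.

Working notes on the series. The shared core is held constant across compound 1 `Cn1c(=O)c(S(=O)(=O)c2ccc(F)cc2)cc2cnc(Nc3cccc4[nH]ccc34)nc21`, compound 2 `Cn1c(=O)c(S(=O)(=O)c2ccc(F)cc2)cc2cnc(Nc3ccc4[nH]cnc4c3)nc21` and compound 3 `Cn1c(=O)c(S(=O)(=O)c2ccc(F)cc2)cc2cnc(Nc3ccc4[nH]ccc4c3)nc21`; only the aryl on the amine nitrogen changes. In a functional assay on DU-145 cells (Homo sapiens) for inhibition, read by trypan blue exclusion, with a stated time of 72 h (a higher number here means a weaker inhibitor, a lower number a stronger inhibitor), compound 1 gives 750 nM, compound 2 gives 10000 nM and compound 3 gives 300 nM. Compound 1 thus stands second highest of the three: a 2.5-fold lower number from compound 1 to compound 3 (0.40 log units; beyond the scatter), a 13-fold higher number from compound 1 to compound 2 (1.12 log units; beyond the scatter), and a 33-fold lower number from compound 2 to compound 3 (1.52 log units; beyond the scatter).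

Compound 4 `Cc1ccc(S(=O)(=O)c2cc3cnc(Nc4cccc5[nH]ccc45)nc3n(C)c2=O)cc1` differs from compound 1 elsewhere: methyl in place of fluoro on an aromatic carbon. Among the measured compounds shown here, none of the measured steps touches the sulfonyl aryl, so no step bears directly on this change, and no step beyond the scatter is expected in this assay in either direction. Compound 4 is therefore estimated at 750 nM, range 300 nM to 2000 nM, an expected step of no change at the digits printed from compound 1 to compound 4 (within the scatter).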

Compound 4, half-maximal inhibitory concentration: 10000 nM
For compound 4 the middle estimate is 13-fold (1.12 log units) below the measured one, and the stated range ends below it.
By their numbers in this assay, from the lowest: compound 3; then compound 1; then compounds 2 and 4 (each within the scatter of the next).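

Among the compounds shown here, the sulfonyl aryl, which no earlier step touched, is not a silent position in this assay: 4-methylphenyl in place of 4-fluorophenyl gives a 13-fold higher number from compound 1 to compound 4 (1.12 log units; beyond the scatter). This step comes from exchanging one heavy atom for another, with no change in the count of hydrogen-bond donors or acceptors and no net charge on either group. Nothing measured here accounts for its size.

From the compounds shown here alone, whether the same step holds with 1H-indol-5-yl on the amine nitrogen remains open. Also open, going by these compounds, is how chloro, methoxy or an amine would read on this aromatic carbon.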